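A few compounds are considered here, and "the series" means these few. Any claim that something is new, unique, unknown or untested is made for them only; others in the source may bear on it.

The measured compounds and their values in a functional assay on EL4 cells (Mus musculus) for inhibition, tested at 100 uM; a higher number here means more inhibition at the concentration tested (going by the name of the read-out), a lower number less inhibition:

Compound 1, `CN(C)c1[nH]ccc2ncnc1-2`, gives 25%.
Compound 2, `CN(C)c1nccc2c1ncn2C1O[C@H](CO)[C@@H](O)[C@H]1O`, gives 10%.
Compound 3, `[N-]=[N+]=Nc1nccc2c1ncn2C1O[C@H](CO)[C@@H](O)[C@H]1O`, reaches only the limit < 5%, which is a limit of this assay and not a number.

Compound 1 has the highest of the two numbers, and compound 2 lies a step below it that goes beyond the scatter. The difference between the two cores of compound 1 and compound 2 is not broken down here. From compound 2 to compound 3 the change is azido in place of dimethylamino on an aromatic carbon, and it brings a number at least 5 percentage points lower from compound 2 to compound 3 (that floor lies within the scatter); compound 3 then sits at the limit of < 5% in this assay, at which 1 of the 3 values shown sits.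

Compound 4, `[N-]=[N+]=Nc1[nH]ccc2ncnc1-2`, is not yet measured in this assay. It differs from compound 1 by azido in place of dimethylamino on an aromatic carbon, the same change as that from compound 2 to compound 3, at the same kind of place. On the strength of the earlier step, a number at least 5 percentage points lower from compound 2 to compound 3 (that floor lies within the scatter), the step from compound 1 to compound 4 is expected to be a number 13 percentage points lower from compound 1 to compound 4 (beyond the scatter). Compound 4 is therefore estimated to give 12% in this assay, within a range from 2% to 24%.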

Compound 4, a percentage reported as inhibition, at one concentration (the size of the read-out at that concentration, not a potency): < 5%
Compound 4 gave a limit, no number; the forecaster's own chance of this, stated with the estimate: 25%; middle value at least 7 percentage points away from the limit.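

In this assay, azido in place of dimethylamino on an aromatic carbon of the core of compound 1 gives a number at least 20 percentage points lower from compound 1 to compound 4 (beyond the scatter). This shows that the change can be read as a clear loss on this core, and set beside the same change on the other core, the two steps stand as follows: the same change on two cores in this assay, a number at least 5 percentage points lower (that floor lies within the scatter) from compound 2 to compound 3 and a number at least 20 percentage points lower (beyond the scatter) from compound 1 to compound 4; the limit leaves it open whether they differ. Compound 3 and compound 4 both end at a limit of the assay and not at a number, so the full size of the change is fixed on neither core, and the series does not show whether it carries over with the same size: the limit of < 5% in this assay, at which 2 of the 4 values shown sit.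

The compounds shown leave open how other groups at this place would read on either core, such as a primary amine, a methoxy group or a longer alkyl chain on the amine. They also leave open what the difference between the cores of compound 1 and compound 2 contributes on its own.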